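A few compounds are considered here, and "the series" means these few. Any claim that something is new, unique, unknown or untested is made for them only; others in the source may bear on it.

Of the compounds shown here, two sharing one core have so far been tested in a functional assay on the whole organism for inhibition, with Mus musculus as the target, with a stated time of 0.5 h; a higher number here means that more compound is needed for the effect, a lower number that less compound is needed. Compound 1 `CC1(C)CC12NC(=O)N(NC(=O)c1ccccc1)C2=O` needs 300 mg/kg, and compound 2 `CC1(C)CC12NC(=O)N(NC(=O)c1ccc(F)cc1)C2=O` needs 300 mg/kg. The step of no change at the digits printed from compound 1 to compound 2 (within the scatter) therefore shows no shift, and compound 2 stands level with compound 1.

Compound 3 `CC1(C)CC12NC(=O)N(NC(=O)c1ccc([N+](=O)[O-])cc1)C2=O` differs from compound 2 by nitro in place of fluoro on an aromatic carbon. Among the measured compounds shown here, the only measured change on the same aromatic ring, no change at the digits printed from compound 1 to compound 2 (within the scatter), left the dose unchanged, so the next change there is expected to move it little, as no change at the digits printed from compound 2 to compound 3 (within the scatter). Compound 3 is estimated at 300 mg/kg, with a range from 150 mg/kg to 600 mg/kg.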

Compound 3, minimum effective dose: 300 mg/kg
The estimate for compound 3 equals the measured number at the digits printed, within the range that was stated.
By their numbers in this assay, from the lowest: compounds 1, 2 and 3 (each within the scatter of the next).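

In this assay the aromatic carbon para to a large group has now carried a second replacement: nitro in place of fluoro gives (no change at the digits printed from compound 2 to compound 3 (within the scatter)) and nitro in place of hydrogen gives (no change at the digits printed from compound 1 to compound 3 (within the scatter)). Hydrogen, fluoro and nitro at this place thus read alike, which the single fluoro step could not show. No measurement here offers an explanation for this. As far as these compounds go, whether an amine, a carboxylic acid or a longer chain at this place would also read alike stays open, as does the effect of changes elsewhere on the shared core.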